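Replacing the benzyl group on the amide of compound 2

The compounds below may be only part of what the source reports. "The series", "measured", "known", "first", "only" and "open" are said of these compounds alone.

In a functional assay on MDA-MB-435 cells (Homo sapiens) for cytotoxicity, read by MTT assay, with a stated time of 72 h (a higher number here means a weaker inhibitor, a lower number a stronger inhibitor), compound 2 `N[C@H]1CC[C@H](Nc2c(C(=O)NCc3ccc(Cl)cc3Cl)nc(Br)c3cccnc23)CC1` gives 5800 nM and compound 1 `COc1ccc(CNC(=O)c2nc(Br)c3cccnc3c2N[C@H]2CC[C@H](N)CC2)cc1` gives 5000 nM, so the two stand level within the scatter. Compound 3 `C[C@H](NC(=O)c1nc(Br)c2cccnc2c1N[C@H]1CC[C@H](N)CC1)c1ccc(F)cc1` carries 1-(4-fluorophenyl)ethyl in place of 2,4-dichlorobenzyl on an amide-type nitrogen. Going by the values given here, one measured step bears on this change: a 1.2-fold higher number from compound 1 to compound 2 (0.06 log units; within the scatter), with 2,4-dichlorophenyl in place of 4-methoxyphenyl on a saturated chain carbon bound to an amide-type nitrogen. That step stays within the scatter. Among the compounds with values here, it covers only the aromatic part of the group, and no measured compound has a defined stereocentre in this group, so the evidence is thin and the range is kept wide. The expected change is small, an estimated 1.2-fold lower number from compound 2 to compound 3 (0.06 log units; within the scatter), with no shift beyond the scatter anticipated. For compound 3 the estimated value is 5000 nM, with an expected range of 2000 nM to 12000 nM.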

Compound 3, half-maximal inhibitory concentration: > 10000 nM
Compound 3: no number, only a limit; the forecaster's own chance of this, stated with the estimate: 10%; middle value at least 2.0-fold (0.30 log units) away from the limit.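

In this assay compound 3 gives > 10000 nM as a limit of the assay and not a number. The steps are therefore floors only, an at least 1.7-fold higher number from compound 2 to compound 3 (0.23 log units; that floor lies within the scatter) and an at least 2.0-fold higher number from compound 1 to compound 3 (0.30 log units; that floor lies within the scatter) and neither establishes a change beyond the scatter, though neither caps its size. Unlike the two benzyl amides, the 1-(4-fluorophenyl)ethyl amide gives no measurable value at this position: the limit of > 10000 nM in this assay, at which 1 of the 3 values shown sits.

This change alters the ring halogens, adds branching on the chain carbon and introduces a defined stereocentre all at once, and the compounds shown do not separate these contributions. From the compounds shown here alone, a 4-fluorobenzyl group and the opposite stereoisomer of 1-(4-fluorophenyl)ethyl on the same amide-type nitrogen remain open, as does the true value of compound 3.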